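Replacing a benzyl with a tert-butyl in a uracil series

The source may report more compounds than this note shows. Statements on the series, on what has been measured and on what is new or still open speak of the compounds shown alone.

Measured compounds:
Compound 1, `O=c1ccn(CCCOC(c2ccccc2)(c2ccccc2)c2ccccc2)c(=O)[nH]1`, gives 313000 nM in an assay on isolated protein for inhibition of Deoxyuridine 5'-triphosphate nucleotidohydrolase, mitochondrial (Homo sapiens); a lower number here means a stronger inhibitor, a higher number a weaker inhibitor.
Compound 2, `O=c1ccn(CCCO[Si](c2ccccc2)(c2ccccc2)c2ccccc2)c(=O)[nH]1`, gives 25000 nM in this assay.
Compound 3, `O=C(NCCCCn1ccc(=O)[nH]c1=O)OCc1ccccc1`, gives > 1000000 nM in this assay.

Compound 3 carries a benzyl on an oxygen next to a carbonyl group, attached through a chain to the shared uracil core. Its result in this assay is not a number but a limit: compound 3 reaches only > 1000000 nM, which is the limit of > 1000000 nM in this assay, at which 1 of the 3 values shown sits. So the weakest reading of the set is compound 3, while compound 2 and compound 1 give numbers that can be compared with one another.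

Compound 4, `CC(C)(C)OC(=O)NCCCCn1ccc(=O)[nH]c1=O`, differs from compound 3 in one place: tert-butyl in place of benzyl on an oxygen next to a carbonyl group. The benzyl that leaves carries the only ring of that side chain, and the tert-butyl that enters carries none. Among the measured compounds, the only one with no ring on that side of the chain is compound 3 itself, and it sits at the limit. Among the measured compounds shown here, no measured pair separates a benzyl from a tert-butyl, so the direction of this change cannot be read from the data. Compound 4 is therefore expected to sit near the same limit, with an expected step that the limit leaves unreadable from compound 3 to compound 4 that stays within the scatter. The estimate for compound 4 is 2000000 nM, with a range from 500000 nM to 10000000 nM.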

Compound 4, inhibition constant: > 1000000 nM
Compound 4: no number, only a limit; the forecaster's own chance of this, stated with the estimate: 75%; the middle value lies beyond the limit too.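

In this assay compound 4 gives > 1000000 nM as a limit of the assay and not a number. Compound 3 also stands at a limit, so no step between compound 3 and compound 4 can be read: the limit of > 1000000 nM in this assay, at which 2 of the 4 values shown sit.

In this assay the compounds shown leave open whether tert-butyl and benzyl on an oxygen next to a carbonyl group differ at all.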